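The source may report more compounds than this note shows. Statements on the series, on what has been measured and on what is new or still open speak of the compounds shown alone.

Compound 1 `O=c1oc2ccccc2cc1C1=NN(c2ccccc2)[C@@H](/C=C/c2ccccc2)C1`: 26.7%
Compound 2 `CN(C)c1ccc([C@H]2CC(c3cc4ccccc4oc3=O)=NN2c2ccccc2)cc1`: 28.4%

In a functional assay on the whole organism (strain albino) for inhibition, with Rattus norvegicus as the target, read by paw edema, with stated times of 1 h and 2 h, at a dose of 200 mg/kg by the oral route (on this read-out higher numbers stand for more inhibition at the one dose given (going by the name of the read-out) and lower numbers for less inhibition), compound 1 gives 26.7% and compound 2 gives 28.4%. Compound 2 holds the top of these two numbers only nominally, since the step of a number 1.7 percentage points higher from compound 1 to compound 2 (within the scatter) lies within the scatter and the two compounds cannot be told apart on this read-out.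

Compound 3 `COc1cccc([C@H]2CC(c3cc4ccccc4oc3=O)=NN2c2ccccc2)c1` is the next compound. Its difference from compound 2 is 3-methoxyphenyl in place of 4-(dimethylamino)phenyl on a saturated ring carbon. Within the data shown here, the only measured step, from compound 1 to compound 2, changed the same saturated ring carbon and produced a shift within the scatter; it exchanged a 2-phenylethenyl for an aryl group and so speaks only loosely to an exchange of one aryl group for another. With no step beyond the scatter recorded, the expected change is a number 1.4 percentage points lower from compound 2 to compound 3 (within the scatter), without a direction. Compound 3 is therefore estimated at 27%, within a range of 15% to 40%.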

Compound 3, a percentage reported as inhibition, in the whole organism at one dose (the size of the read-out at that dose, not a potency): 38.3%
Beside the measured number, compound 3's estimate is 11.3 percentage points below it; measured number inside the range.
By their numbers in this assay, from the lowest: compounds 1, 2 and 3 (each within the scatter of the next, the first and the last beyond it).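

In this assay, the saturated ring carbon now yields its first step beyond the scatter, a modest one: a number 11.6 percentage points higher from compound 1 to compound 3 (beyond the scatter), with 3-methoxyphenyl in place of 2-phenylethenyl. Among these compounds, exchanging one aryl group for another at this carbon does not separate the compounds, the step being a number 9.9 percentage points higher from compound 2 to compound 3 (within the scatter), so only the pair with the 2-phenylethenyl compound shows that this position can move the read-out. No measurement available here bears on why the numbers fall this way.

On these data alone, whether 4-methoxyphenyl at this carbon would read like 3-methoxyphenyl remains open, as does the outcome of a carboxylic acid or an aminoethyl chain on that aryl ring. As far as these compounds go, the phenyl group on the neighbouring ring atom also stays the same throughout, so its contribution is untested by these compounds.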